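Adding a methyl to the methylamino side chain

A few compounds are considered here, and "the series" means these few. Any claim that something is new, unique, unknown or untested is made for them only; others in the source may bear on it.

Values in a functional assay on A2780 cells (Homo sapiens) for antiproliferative activity, read by MTT assay, with a stated time of 48 h (on this read-out lower numbers stand for stronger inhibition and higher numbers for weaker inhibition), are as follows
Compound 1 `COc1ccc(C(=O)c2ccc(OC)c3c2C=CC(C)(C)O3)c(NC(=O)CBr)c1` gives 2150 nM
Compound 2 `CNCC(=O)Nc1cc(OC)ccc1C(=O)c1ccc(OC)c2c1C=CC(C)(C)O2` gives 1590 nM
Compound 3 `CNCC(=O)Nc1cc(OC)ccc1C(=O)c1ccc2c(c1)C=CC(C)(C)O2` gives 850 nM

Compound 2 at 1590 nM sits in the middle of these three values, within the usual scatter of both compound 1 and compound 3. Compound 4 `COc1ccc(C(=O)c2ccc(OC)c3c2C=CC(C)(C)O3)c(NC(=O)CN(C)C)c1` is not yet measured. It differs from compound 2 by methyl in place of hydrogen on an amine nitrogen and so carries methyl in place of hydrogen on an amine nitrogen, which turns methylamino into dimethylamino.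

Within the data shown here, one measured step bears on this part of the molecule, and it is a 1.4-fold lower number from compound 1 to compound 2 (0.13 log units; within the scatter) for methylamino in place of bromo on a saturated chain carbon bound to a carbonyl carbon. Among the measured compounds shown here, no measured compound yet shows what a methyl on that nitrogen does, so this is only indirect evidence. For the measured compounds named here, with a 1.4-fold lower number from compound 1 to compound 2 (0.13 log units; within the scatter) as the only guide, no step beyond the scatter is expected in this assay in either direction. The expected step is a 1.1-fold lower number from compound 2 to compound 4 (0.03 log units; within the scatter) and it remains an estimate. For compound 4 the estimated value is 1500 nM with an expected range of 650 nM to 3500 nM around it.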

Compound 4, half-maximal inhibitory concentration: 3990 nM
The estimate for compound 4 lay 2.7-fold (0.42 log units) below the measured number; the measured number lies above the stated range.
By their numbers in this assay, from the lowest: compounds 3, 2, 1 and 4 (each within the scatter of the next, the first and the last beyond it).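

In this assay, among these compounds, the step of a 2.5-fold higher number from compound 2 to compound 4 (0.40 log units; beyond the scatter) gives the first direct reading of a methyl in place of hydrogen on this amine nitrogen, and it shows a modest loss of antiproliferative activity that lies beyond the scatter. The earlier step from bromo to methylamino stayed within the scatter, so this side chain now shows a measurable response to a change of a single methyl. The other new step, a 1.9-fold higher number from compound 1 to compound 4 (0.27 log units; within the scatter), lies within the scatter, so dimethylamino and bromo cannot be told apart on this chain.

The data available here give no reason for the loss. From the compounds shown here alone, it remains open whether an unsubstituted amino group, an ethyl on the nitrogen or a piperidine ring would continue this trend, and whether the same methyl would have a similar effect on the core of compound 3.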